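The source may report more compounds than this note shows. Statements on the series, on what has been measured and on what is new or still open speak of the compounds shown alone.

Three compounds of the series have numbers in a functional assay on HeLa cells for agonist activity at 5-hydroxytryptamine receptor 6 (Homo sapiens), read by cAMP accumulation and immunoassay; on this read-out higher numbers stand for an effect only at larger amounts of compound and lower numbers for an effect already at smaller amounts. Compound 2 `O=S(=O)(c1cccc(Cl)c1)c1cn(C2CCCNC2)c2ncccc12` gives 30 nM, the lowest of the three numbers. Compound 3 `CN1CCCC(n2cc(S(=O)(=O)c3cc(Cl)cc(Cl)c3)c3cccnc32)C1` gives 38.7 nM, which lies within the scatter of compound 2. Compound 1 `O=S(=O)(C1=C(Cl)NC2SC=CN12)c1cn(C2CCNC2)c2ncccc12` gives 80 nM, which lies beyond the scatter from compound 2. Compound 4 `O=S(=O)(C1=C(Cl)NC2SC=CN12)c1cn(C2CCCNC2)c2ncccc12` is not yet measured; it differs from compound 2 by a group of 9 heavy atoms (5 carbon, 2 nitrogen, 1 sulfur, 1 chlorine; 2 five-membered non-aromatic rings with 2 hetero atoms each) in place of a group of 7 heavy atoms (6 carbon, 1 chlorine; one six-membered aromatic ring of carbon only), on a sulfonyl sulfur. Among the measured compounds shown here, no single-place step between measured compounds is known, so the size of this step is uncertain. Compound 1 carries the same entering group and gives 80 nM; on that basis the expected step is a 2.0-fold higher number from compound 2 to compound 4 (0.30 log units; within the scatter), a moderate rise in the number near the edge of the scatter. Compound 4 is therefore estimated at 60 nM, with a range of 25 nM to 150 nM.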

Compound 4, half-maximal effective concentration: 66 nM
Compound 4: middle estimate off by 1.1-fold (0.04 log units), on the low side, within the range that was stated.
By their numbers in this assay, from the lowest: compounds 2, 3, 4 and 1 (each within the scatter of the next, the first and the last beyond it).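

In this assay, replacing 3-chlorophenyl on the sulfonyl sulfur with the group of two five-membered non-aromatic rings gives a 2.2-fold higher number from compound 2 to compound 4 (0.34 log units; beyond the scatter), so this position shows a modest step beyond the scatter. On the aromatic nitrogen, piperidin-3-yl in place of pyrrolidin-3-yl gives a 1.2-fold lower number from compound 1 to compound 4 (0.08 log units; within the scatter), so with this sulfonyl group the two rings are not separated. The data offer no explanation for either step. As far as these compounds go, it remains open whether the nitrogen step holds with 3-chlorophenyl on the sulfonyl sulfur. Also open, from the compounds shown here alone, is how a simple amine or a carboxylic acid on that sulfur would compare.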